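The compounds below may be only part of what the source reports. "The series", "measured", "known", "first", "only" and "open" are said of these compounds alone.

Measured compounds:
- compound 1 `c1csc(-c2ccccc2NCC2=NCCN2)c1`; in a functional assay for activation of Alpha-1D adrenergic receptor (Homo sapiens) (a higher number here means that more compound is needed for the effect, a lower number that less compound is needed), compound 1 gives 18.2 nM
- compound 2 `Cc1nc(-c2ccccc2NCC2=NCCN2)co1`; in this assay compound 2 gives < 5020 nM, a limit of the assay and not a number
- compound 3 `c1ccc(-c2cnoc2)c(NCC2=NCCN2)c1`; in this assay compound 3 gives < 100000 nM, likewise a limit and not a number

Compound 3 therefore stands on a limit only: the assay reports no number for it, and compound 1 is the only one of the three with a real value. None of the steps among them can be sized: a step that the limit leaves unreadable from compound 1 to compound 2, a step that the limit leaves unreadable from compound 1 to compound 3 and a step that the two limits leave unreadable from compound 2 to compound 3. The reason lies in the limit of < 100000 nM in this assay, at which 1 of the 3 values shown sits, and (the limit of < 5020 nM in this assay, at which 1 of the 3 values shown sits).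

Compound 4 `Cc1ccc(-c2ccccc2NCC2=NCCN2)o1` differs from compound 3 by 5-methylfuran-2-yl in place of 1,2-oxazol-4-yl on an aromatic carbon. No measured step can be read, so none gives a size to carry over. The entering 5-methylfuran-2-yl ring is nearer in kind to the thiophen-2-yl of compound 1 than to the 1,2-oxazol-4-yl of compound 3, so compound 4 is expected to land close to the value of compound 1, 18.2 nM. Compound 4 is estimated at 30 nM, between 5 nM and 300 nM. The estimated step that the limit leaves unreadable from compound 3 to compound 4 is toward a lower number, though its true size stays unreadable against a limit.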

Compound 4, half-maximal effective concentration: < 2000 nM
Compound 4 was reported as a limit; the forecaster's own chance of this, stated with the estimate: 15%; the middle value is on the limit's open side.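

In this assay compound 4 gives < 2000 nM, a limit of the assay and not a number. The steps joining compound 4 to compound 1, compound 2 and compound 3 therefore cannot be read: the limit of < 2000 nM in this assay, at which 1 of the 4 values shown sits.

The compounds shown leave open how the 5-methylfuran-2-yl of compound 4 compares with the thiophen-2-yl of compound 1, which alone has a real value, 18.2 nM.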